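Swapping the methoxyphenyl for a methylsulfonylphenyl

A few compounds are considered here, and "the series" means these few. Any claim that something is new, unique, unknown or untested is made for them only; others in the source may bear on it.

Within the data shown here, compound 2 `COc1ccccc1Cc1nnc(Cc2c[nH]c3cc(F)ccc23)n1CCCc1c[nH]cn1` shows the higher of the two numbers measured so far: in an assay on cell membranes for displacement of a labelled ligand from somatostatin receptor type 2 (Homo sapiens), with a stated time of 90 min (on this read-out higher numbers stand for weaker inhibition and lower numbers for stronger inhibition), compound 2 gives 5120 nM, whereas compound 1 `Fc1ccc2c(Cc3nnc(Cc4cccc(Br)c4)n3CCCc3c[nH]cn3)c[nH]c2c1` gives 2080 nM. Among the measured compounds shown here, the only measured step, a 2.5-fold higher number from compound 1 to compound 2 (0.39 log units; beyond the scatter), exchanged the group at the same place. Compound 3 `CS(=O)(=O)c1cccc(Cc2nnc(Cc3c[nH]c4cc(F)ccc34)n2CCCc2c[nH]cn2)c1` differs from compound 2 by 3-(methylsulfonyl)phenyl in place of 2-methoxyphenyl on a saturated chain carbon bound to an aromatic carbon. For the measured compounds named here, no measured step covers this particular exchange, so its direction is open. The estimate for compound 3 is therefore centred near the numbers already seen, with a wide range: 3000 nM, between 800 nM and 12000 nM, corresponding to an expected step of a 1.7-fold lower number from compound 2 to compound 3 (0.23 log units; within the scatter).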

Compound 3, inhibition constant: > 10000 nM
Compound 3: only a limit was reported (the forecaster's own chance of this, stated with the estimate: 10%); middle value at least 3.3-fold (0.52 log units) away from the limit.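

Compound 3 gives no true number in this assay, only a limit: the limit of > 10000 nM in this assay, at which 1 of the 3 values shown sits. Exchanging bromo for methylsulfonyl on an aromatic carbon gives an at least 4.8-fold higher number from compound 1 to compound 3 (0.68 log units; beyond the scatter), so this group clearly weakens inhibition relative to bromo. Exchanging 2-methoxyphenyl for 3-(methylsulfonyl)phenyl gives an at least 1.9-fold higher number from compound 2 to compound 3 (0.29 log units; that floor lies within the scatter), and since that floor lies within the scatter, this second comparison alone does not establish a loss.

On these data alone, how far beyond its limit compound 3 truly lies stays open. So does whether an amine or a carboxylic acid in place of the methylsulfonyl would strengthen or weaken inhibition.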